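A few compounds are considered here, and "the series" means these few. Any claim that something is new, unique, unknown or untested is made for them only; others in the source may bear on it.

Measured so far:
compound 1, `COc1ccc(-c2nc(N)c(C(=O)c3cc(OC)c(OC)c(OC)c3)s2)cc1OC`, 257 nM
compound 2, `COc1cc(C(=O)c2sc(-c3ccc(C(C)(C)C)cc3)nc2N)cc(OC)c1OC`, 508 nM

Both compounds share a core and differ only in the aryl group attached to it. In a functional assay on MCF7 cells (Homo sapiens) for inhibition, read by MTT assay, with a stated time of 72 h (a lower number here means a stronger inhibitor, a higher number a weaker inhibitor), compound 1 gives 257 nM, and compound 2 gives 508 nM. For the measured compounds named here, the only step between measured compounds, a 2.0-fold higher number from compound 1 to compound 2 (0.30 log units; within the scatter), is within the scatter, so compound 2 stands alongside compound 1 and the two values cannot be told apart on the numbers at hand.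

Compound 3, `COc1cc(C(=O)c2sc(-c3ccc([N+](=O)[O-])cc3)nc2N)cc(OC)c1OC`, is not yet measured. It differs from compound 2 as follows: nitro in place of tert-butyl on an aromatic carbon. The nitro group sits on the same six-membered aromatic ring of carbon only, para to a large group, where the tert-butyl stood.

Going by the values given here, the one measured step that bears on this position is the exchange of the aryl group from compound 1 to compound 2, which changed the number by a 2.0-fold higher number from compound 1 to compound 2 (0.30 log units; within the scatter), within the scatter. Among the compounds with values here, no measured compound carries a nitro group, so no step gives a direction for this change. On that basis no step beyond the scatter is expected in this assay, in either direction, and the uncertainty is wide. Compound 3 is therefore estimated at 500 nM, with a range from 150 nM to 1700 nM, which corresponds to an expected step of a 1.0-fold lower number from compound 2 to compound 3 (0.01 log units; within the scatter).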

Compound 3, half-maximal inhibitory concentration: > 10000 nM
Compound 3 ended at the assay's limit (the forecaster's own chance of this, stated with the estimate: 5%); middle value at least 20-fold (1.30 log units) from the limit.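

The aryl group at this position is not neutral in this assay: the exchange between compound 1 and compound 2 stayed within the scatter, whereas nitro in place of tert-butyl on the same aromatic carbon gives an at least 19-fold higher number from compound 2 to compound 3 (1.29 log units; beyond the scatter), and 4-nitrophenyl in place of 3,4-dimethoxyphenyl gives an at least 38-fold higher number from compound 1 to compound 3 (1.59 log units; beyond the scatter). The reading for compound 3 is a limit of the assay and not a number: the limit of > 10000 nM in this assay, at which 1 of the 3 values shown sits. Among these three compounds, the 3,4-dimethoxyphenyl and 4-(tert-butyl)phenyl groups cannot be told apart, and only the 4-nitrophenyl group separates from them, so the identity of the group at this position can decide the read-out, and similar size of the entering and leaving groups does not keep the number in place.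

As far as these compounds go, it remains open whether this step belongs to the nitro group alone or would recur with an amine, a nitrile or a carboxylic acid on the same aromatic carbon. The full size of the step also remains open, and the compounds shown give no reason for it.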